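The source may report more compounds than this note shows. Statements on the series, on what has been measured and on what is new or still open speak of the compounds shown alone.

- Compound 1 `COc1cc(/C=N/Nc2nc(-c3ccc(Br)cc3)cs2)cc(Br)c1OC` gives 27900 nM
- Compound 2 `COc1cc(/C=N/Nc2nc(-c3ccc(Br)cc3)cs2)c(Br)c(Br)c1OC` gives > 100000 nM (a limit of the assay, not a number)

For the measured compounds named here, in a functional assay on U-87MG ATCC cells for inhibition, with U-87 MG (Homo sapiens) as the target, read by MTT assay, with a stated time of 48 h (on this read-out higher numbers stand for weaker inhibition and lower numbers for stronger inhibition), compound 1 gives 27900 nM, which is the only true number so far. Compound 2 reads > 100000 nM, and this is a limit. Going by the values given here, the one measured step is an at least 3.5-fold higher number from compound 1 to compound 2 (0.55 log units; beyond the scatter). It shows that a single added group can change the read-out in this series, but it concerns a different group from the one changing next, so it offers only weak guidance.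

Compound 3 `COc1ccccc1-c1csc(N/N=C/c2cc(Br)c(OC)c(OC)c2)n1` carries 2-methoxyphenyl in place of 4-bromophenyl on an aromatic carbon. Among the compounds with values here, no measured step involves this exchange, so neither direction is favoured, and no step beyond the scatter is expected in this assay. The estimate therefore stays anchored on compound 1 at 27900 nM, with a wide range to reflect the thin evidence. The expected move is a 1.1-fold higher number from compound 1 to compound 3 (0.03 log units; within the scatter). Compound 3 is estimated at 30000 nM, and its value is expected to fall between 9000 nM and 100000 nM.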

Compound 3, half-maximal inhibitory concentration: > 100000 nM
Compound 3: no number, only a limit; the forecaster's own chance of this, stated with the estimate: 20%; middle value at least 3.3-fold (0.52 log units) from the limit.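

This exchange shows that the position on the aromatic carbon next to the ring nitrogen is not indifferent to what it carries: in this assay, replacing 4-bromophenyl with 2-methoxyphenyl gives an at least 3.5-fold higher number from compound 1 to compound 3 (0.55 log units; beyond the scatter). Compound 3 reads > 100000 nM, which is a limit of the assay and not a number. The step therefore gives a direction and a minimum size, and its full size cannot be read because of one feature of these results: the limit of > 100000 nM in this assay, at which 2 of the 3 values shown sit.

This single exchange removes the bromine, brings in a methoxy group and changes where the substituent sits on the phenyl ring, so the compounds shown cannot tell which of these changes matters; plain phenyl and 4-methoxyphenyl at this position would help to separate them. For the compounds shown here, it also remains open whether any group here can give a lower number than compound 1 at 27900 nM, for example 4-aminophenyl or 4-carboxyphenyl, since the only change seen so far at this position moves the read-out towards weaker inhibition.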